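This account rests on a few compounds, and the source may have more. Where it says the series, first, only, none or still open, it means among the compounds named here.

Working notes on the series. Going by the values given here, compound 1 `O=C(CCCSc1nc2cc(Cl)ccc2o1)N1CCCC1` has been measured in an ADME assay on microsomes from liver (Homo sapiens) for metabolic stability, read by LC-MS, using NADPH, with a stated time of 45 min, tested at 0.5 uM (a lower number here means slower removal, a higher number faster removal of the compound), where compound 1 gives 3.4 mL/min/g; among the values at hand it is the only one reported as a number. Compound 2 `Cc1nc(SCCC(=O)N2CCCC2)oc1C` returns only a limit of the assay, (the limit of < 0.4 mL/min/g in this assay, at which 1 of the 2 values shown sits), and in this assay compound 2 sits at < 0.4 mL/min/g, which is a limit and not a number. Among the compounds with values here, no two measured compounds differ in a single place, so no measured step is available to set a scale for the change now in question.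

Compound 3 `Clc1ccc2oc(SCCCN3CCCC3)nc2c1` is not yet measured in this assay. Its difference from compound 1 is pyrrolidin-1-yl in place of (pyrrolidin-1-yl)carbonyl on a saturated chain carbon, three bonds along the chain from a sulfur. Within the data shown here, with no measured step to lean on, the expectation rests on compound 1 alone: an upward step from compound 1 to compound 3 of a 1.5-fold higher number from compound 1 to compound 3 (0.17 log units; within the scatter) is expected, of a size near the edge of the usual scatter. Compound 3 is therefore expected to give 5 mL/min/g in this assay, with a likely range from 1.7 mL/min/g to 15 mL/min/g.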

Compound 3, intrinsic clearance in a liver preparation (reported as CLH), per the amount of preparation that the assay uses: 1.9 mL/min/g
Compound 3: middle estimate off by 2.6-fold (0.42 log units), on the high side; low and high end bracket the measured number.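

Going by these compounds alone, the only measured step at this place in this assay is a 1.8-fold lower number from compound 1 to compound 3 (0.25 log units; within the scatter), and it lies within the scatter. At this place on a saturated chain carbon, three bonds along the chain from a sulfur, pyrrolidin-1-yl in place of (pyrrolidin-1-yl)carbonyl on the core of compound 1 therefore gives no change that can be told apart from repeat measurement. Nothing measured here gives a cause for this step.

On these data alone, whether other groups at this place, such as a carboxylic acid, a morpholine ring or a longer chain, would also stay within the scatter remains open. As far as these compounds go, whether the change carries over to the core of compound 2 is also open, and the value of compound 2 is a limit and not a number.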